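Swapping the Side Chain of a Purine Glycinamide Ester

The compounds below may be only part of what the source reports. "The series", "measured", "known", "first", "only" and "open" are said of these compounds alone.

Measured compounds:
- compound 1, `NC(=O)CC[C@H](NC(=O)CN(c1ncnc2c1ncn2C1CCCCO1)C1CC1)C(=O)OCc1ccccc1`: 47%
- compound 2, `O=C(OCc1ccccc1)[C@@H]1CCCN1C(=O)CN(c1nc(Cl)nc2[nH]cnc12)C1CC1`: 33.2%
- compound 3, `O=C(O)CC[C@H](NC(=O)CN(c1nc(Cl)nc2[nH]cnc12)C1CC1)C(=O)O`: 26.8%

In a functional assay on the whole organism (Tail, strain ICR) with Mus musculus as the target, in the tail flick test, with a stated time of 30 min, at a dose of 25 umol/kg by the oral route (on this read-out lower numbers stand for a weaker effect and higher numbers for a stronger effect at the one dose given), compound 1 gives 47%, the highest of the three numbers, with compound 2 and compound 3 both falling beyond the usual scatter below it. Compound 4, `C[C@@H](O)[C@H](NC(=O)CN(c1ncnc2c1ncn2C1CCCCO1)C1CC1)C(=O)OCc1ccccc1`, has not been measured in this assay. It differs from compound 1 in one place: 1-hydroxyethyl in place of 2-carbamoylethyl on a saturated chain carbon bound to an amide-type nitrogen and a carbonyl carbon. Among the measured compounds shown here, no measured pair shows the effect of this change on the shared core, so the step from compound 1 to compound 4 is open. A modest fall seems most likely, and a step of a number 9 percentage points lower from compound 1 to compound 4 (within the scatter) is expected. Compound 4 is estimated at 38% in this assay, within 20% to 55%.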

Compound 4, a percentage reported as activity, at one dose (the size of the read-out at that dose, not a potency): 23.6%
Estimate against measurement, compound 4: 14.4 percentage points above; measured number inside the range.
By their numbers in this assay, from the lowest: compounds 4, 3 and 2 (each within the scatter of the next); then compound 1.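

In this assay, among the compounds shown here, putting 1-hydroxyethyl in place of 2-carbamoylethyl on a saturated chain carbon bound to an amide-type nitrogen and a carbonyl carbon gives a number 23.4 percentage points lower from compound 1 to compound 4 (beyond the scatter) and so offers the first direct reading of this position. With the shared core unchanged, this one side chain swap is enough to move the number beyond the usual scatter. Nothing measured here accounts for the fall.

A single replacement cannot separate losing the 2-carbamoylethyl group from gaining the 1-hydroxyethyl group. On these data alone, how an amine or a longer chain ending in a carbamoyl group would read at this position stays open.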